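A cyclic amine in place of an open one

A few compounds are considered here, and "the series" means these few. Any claim that something is new, unique, unknown or untested is made for them only; others in the source may bear on it.

Compound 1 `CCNc1nc2c(C(=O)N[C@@H]3CN4CCC3CC4)cccc2o1`: 36.4 nM
Compound 2 `CN(C)c1nc2c(C(=O)N[C@@H]3CN4CCC3CC4)cccc2o1`: 18.2 nM
Compound 3 `CC(C)N(C)c1nc2c(C(=O)N[C@@H]3CN4CCC3CC4)cccc2o1`: 66.5 nM

Three compounds share a core and differ only in the amine on the aromatic carbon. In an assay on isolated protein for binding affinity to 5-hydroxytryptamine receptor 3A (Homo sapiens) (a higher number here means a weaker inhibitor, a lower number a stronger inhibitor), compound 3 gives the highest of the three values. Its nearest neighbour is compound 1, and the step of a 1.8-fold higher number from compound 1 to compound 3 (0.26 log units; within the scatter) stays within the scatter; the step of a 3.7-fold higher number from compound 2 to compound 3 (0.56 log units; beyond the scatter) is the only one beyond it. The remaining step, a 2.0-fold lower number from compound 1 to compound 2 (0.30 log units; within the scatter), is within the scatter.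

Compound 4 `C[C@H]1COC[C@H](C)N1c1nc2c(C(=O)N[C@@H]3CN4CCC3CC4)cccc2o1` is not yet measured. It differs from compound 3 by 3,5-dimethylmorpholin-4-yl in place of isopropyl(methyl)amino on an aromatic carbon. The step that bears most directly on this change is a 3.7-fold higher number from compound 2 to compound 3 (0.56 log units; beyond the scatter), where a larger substituent on the nitrogen raised the number moderately; the new group is larger still, with its two methyl groups on the ring. The other steps say little about a ring at this position, so the expectation rests on a single step. Compound 4 is therefore expected to give a somewhat higher number than compound 3, with the step of a 1.7-fold higher number from compound 3 to compound 4 (0.22 log units; within the scatter) as the estimate. The estimated value for compound 4 in this assay is 110 nM, in a range from 35 nM to 350 nM.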

Compound 4, inhibition constant: 6.8 nM
For compound 4 the middle estimate is 16-fold (1.21 log units) above the measured one; the measured number lies below the stated range.
By their numbers in this assay, from the lowest: compound 4; then compounds 2, 1 and 3 (each within the scatter of the next, the first and the last beyond it).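

In this assay, the change to 3,5-dimethylmorpholin-4-yl brings a clear drop, with a 9.8-fold lower number from compound 3 to compound 4 (0.99 log units; beyond the scatter), and the same group also stands apart from the two smaller open amines, with a 2.7-fold lower number from compound 2 to compound 4 (0.43 log units; beyond the scatter) and a 5.4-fold lower number from compound 1 to compound 4 (0.73 log units; beyond the scatter), which makes compound 4 the strongest of the four. This position on the aromatic carbon therefore does not simply penalise a larger amine: the rise seen with a 3.7-fold higher number from compound 2 to compound 3 (0.56 log units; beyond the scatter) holds among the open amines, while compound 4, with the largest group of the set, goes against that trend. No measurement at hand accounts for this reversal.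

The compounds shown cannot separate the contributions of the ring, the ring oxygen and the two methyl groups, and a comparison of unsubstituted morpholin-4-yl with 3,5-dimethylpiperidin-1-yl would begin to divide them. On these data alone, the role of the two defined stereocentres also stays open, as only one arrangement of the methyl groups appears here.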